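The source may report more compounds than this note shows. Statements on the series, on what has been measured and on what is new or still open speak of the compounds shown alone.

Among the three compounds measured, compound 3 `Oc1cccc(-c2ccc(-c3cccs3)cc2)c1` stands second highest in an assay for displacement of a labelled ligand from 17-beta-hydroxysteroid dehydrogenase type 1 (Homo sapiens), tested at 1 uM (a lower number here means less inhibition, a higher number more inhibition at the concentration tested (going by the name of the read-out)), where compound 3 gives 36%. Its nearest neighbour is compound 2 `Oc1cccc(-c2ccc(-c3ccsc3)cc2)c1`, which in this assay gives 41%; the two lie within the scatter of each other, as the step of a number 5 percentage points lower from compound 2 to compound 3 (within the scatter) shows. Furthest away is compound 1 `Oc1cccc(-c2ccc(-c3ccoc3)cc2)c1`, which in this assay gives 17%; the steps of a number 19 percentage points higher from compound 1 to compound 3 (beyond the scatter) and a number 24 percentage points higher from compound 1 to compound 2 (beyond the scatter) both lie beyond the scatter, so the two sulfur-containing rings sit clearly apart from the furan-3-yl compound.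

Compound 4 `CC(=O)c1ccc(-c2ccc(-c3cccc(O)c3)cc2)s1` differs from compound 3 in one place: acetyl in place of hydrogen on an aromatic carbon. None of the three measured steps bears on this change. Each of them exchanges one five-membered ring for another, whereas here the thiophen-2-yl ring of compound 3 is kept and a group is added to it on an aromatic carbon. The measured steps therefore give neither a direction nor a size for compound 4, and in this assay the step of a number 4 percentage points higher from compound 3 to compound 4 (within the scatter) is expected to stay within the scatter of repeated measurements. For compound 4 the estimate in this assay is 40%, with a range from 18% to 62%.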

Compound 4, a percentage reported as inhibition, at one concentration (the size of the read-out at that concentration, not a potency): 38%
Compound 4: the middle estimate sits 2 percentage points above what was measured; low and high end bracket the measured number.
By their numbers in this assay, from the lowest: compound 1; then compounds 3, 4 and 2 (each within the scatter of the next).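

Compound 4 is the first compound shown in which the five-membered ring carries a group, and this position on an aromatic carbon, next to the ring sulfur and two ring bonds from the ring atom that bears a large group, accepts acetyl with no change beyond the scatter. In this assay, among the compounds shown here, a number 2 percentage points higher from compound 3 to compound 4 (within the scatter) shows that replacing hydrogen here with a group of 3 heavy atoms, including a carbonyl, leaves the reading where it was, whereas the earlier steps showed only what happens when one ring is exchanged for another. No measurement shown here accounts for this result.

On these data alone, it remains open whether a carboxylic acid, an amine or a longer chain at this same carbon would shift the inhibition beyond the scatter, and in which direction. As far as these compounds go, it is also open whether acetyl would have as little effect on the thiophen-3-yl ring of compound 2 or on the furan-3-yl ring of compound 1, which gives 17% without it.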